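The source may hold more compounds than are shown below. What is called first, only, known or untested is meant among the compounds shown, and "the series" means these compounds.

Measured compounds:
compound 1 `CC/C=C\[C@H](C)[C@H](OC(N)=O)[C@@H](C)[C@H](O)[C@@H](C)C/C(C)=C\[C@H](C)[C@@H](O)[C@@H](C)/C=C\[C@@H](O)C[C@@H]1OC(=O)[C@H](C)[C@@H](O)[C@H]1C` gives 7 nM
compound 2 `CC/C=C\[C@H](C)[C@H](OC(N)=O)[C@@H](C)[C@H](O)[C@@H](C)C/C(C)=C\[C@H](C)[C@@H](O)[C@@H](C)/C=C\[C@@H](O)C[C@H](O)[C@H](C)C[C@H](C)C(=O)OC` gives 4000 nM
compound 3 `CC/C=C\[C@H](C)[C@H](OC(N)=O)[C@@H](C)[C@H](O)[C@@H](C)C/C(C)=C\[C@H](C)[C@@H](O)[C@@H](C)/C=C\[C@@H](O)C[C@H]1CCC(=O)O1` gives 46 nM

In a functional assay on A549 cells (Homo sapiens) for antiproliferative activity (on this read-out higher numbers stand for weaker inhibition of growth and lower numbers for stronger inhibition of growth), compound 3 stands second highest of the three numbers. Its nearest neighbour is compound 1, reached by a 6.6-fold higher number from compound 1 to compound 3 (0.82 log units; beyond the scatter); its furthest is compound 2, reached by an 87-fold lower number from compound 2 to compound 3 (1.94 log units; beyond the scatter). Both of these steps exchange the group on the saturated chain carbon, and the largest of all, a 570-fold higher number from compound 1 to compound 2 (2.76 log units; beyond the scatter), shows how much that position can move the number.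

Compound 4 `CC/C=C\[C@H](C)[C@H](OC(N)=O)[C@@H](C)[C@H](O)[C@@H](C)C/C(C)=C\[C@H](C)[C@@H](O)[C@@H](C)/C=C\[C@H](O)C[C@@H]1CCC(=O)O1` is the next compound. It differs from compound 3 as follows: the two compounds have the same atoms and bonds and differ only in configuration as drawn: 2 of 13 stereo elements differ; a stereocentre at a saturated chain carbon is drawn S in compound 3 and R in compound 4; a stereocentre at a saturated ring carbon is drawn R in compound 3 and S in compound 4. For the measured compounds named here, no measured step in this set changes configuration alone; every step so far exchanges one group for another, so the steps to hand tell the weight of the position but not of its configuration. The two inverted stereocentres sit at the saturated chain carbon and the saturated ring carbon of the five-membered non-aromatic ring with 1 hetero atom, the same part of the molecule where the group exchanges acted strongly.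

Going by the values given here, with no direct precedent, a change towards a weaker result is expected, of modest size, and the uncertainty is wide. The step from compound 3 to compound 4 is estimated as a 4.3-fold higher number from compound 3 to compound 4 (0.64 log units; beyond the scatter). For compound 4 in this assay the expected value is 200 nM, with a range from 30 nM to 1500 nM.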

Compound 4, concentration for 50% growth inhibition: 4000 nM
Compound 4: the middle estimate sits 20-fold (1.30 log units) below what was measured; the measured number lies above the stated range.
By their numbers in this assay, from the lowest: compound 1; then compound 3; then compounds 2 and 4 (each within the scatter of the next).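

Configuration alone carries a large effect here: in this assay, an 87-fold higher number from compound 3 to compound 4 (1.94 log units; beyond the scatter). This step is larger than the group exchange a 6.6-fold higher number from compound 1 to compound 3 (0.82 log units; beyond the scatter), so keeping the five-membered non-aromatic ring with 1 hetero atom does not by itself keep the number low, and the way the saturated chain carbon and the saturated ring carbon are drawn matters at least as much as the modest change of ring group. The step can be assigned to configuration and to no other structural change because nothing else separates the pair: the fact that compounds 3 and 4 differ only in the configuration as drawn.

The two stereocentres invert together, so the compounds shown do not divide the step between the saturated chain carbon and the saturated ring carbon, and they do not tell whether inverting one alone would give a step of similar size. Also open, on these data alone, is whether the same dependence on configuration holds for the six-membered ring group of compound 1, or for a carboxylic acid or an amine carried on the same saturated chain carbon.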